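The source may hold more compounds than are shown below. What is called first, only, known or untested is meant among the compounds shown, and "the series" means these compounds.

In a functional assay (trachea) with Cavia porcellus as the target (a higher number here means that more compound is needed for the effect, a lower number that less compound is needed), compound 1 (`CCCn1c(=O)n(CCC#N)c(=O)c2[nH]cnc21`) gives 1700 nM and compound 2 (`CCCn1c(=O)n(C)c(=O)c2[nH]cnc21`) gives 1600 nM, so the two stand level within the scatter. Compound 3 (`C=CCCn1cnc2c1c(=O)n(C)c(=O)n2CCC`) starts from compound 2 and puts but-3-en-1-yl in place of hydrogen on an aromatic nitrogen. Within the data shown here, the only measured step is a 1.1-fold lower number from compound 1 to compound 2 (0.03 log units; within the scatter), where hydrogen replaces cyanomethyl on a saturated chain carbon bound to an aromatic nitrogen. That step shows a change in a chain leaving this assay almost untouched, but it is a different change in a different place, so it offers only weak guidance. Among the measured compounds shown here, no measured compound shows what happens when this aromatic nitrogen loses its hydrogen. No shift beyond the scatter is therefore expected, and the estimated step is a 1.1-fold lower number from compound 2 to compound 3 (0.03 log units; within the scatter), with wide uncertainty in either direction. For compound 3 the expected value is 1500 nM, with an estimated range from 400 nM to 6000 nM.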

Compound 3, half-maximal effective concentration: 16800 nM
Beside the measured number, compound 3's estimate is 11-fold (1.05 log units) below it; measured number outside the range, above it.
By their numbers in this assay, from the lowest: compounds 2 and 1 (each within the scatter of the next); then compound 3.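

In this assay, the aromatic nitrogen of the five-membered ring proves to be a sensitive position: but-3-en-1-yl in place of its hydrogen gives an 11-fold higher number from compound 2 to compound 3 (1.02 log units; beyond the scatter) and so means that much more compound is needed for the effect. The earlier change in a chain elsewhere on the core gave only a 1.1-fold lower number from compound 1 to compound 2 (0.03 log units; within the scatter) and showed no such sensitivity, so the shared core does not tolerate every change equally. No measurement at hand accounts for the size of this step.

Only one group on this nitrogen is shown, so it stays open whether the step comes from losing the hydrogen or from the but-3-en-1-yl group itself. An ethyl group or a saturated butyl chain at this nitrogen, or a chain ending in an amine, would help to tell these apart.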